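Replacing Nitro with Methyl: Expected Cell Tolerance

The compounds below may be only part of what the source reports. "The series", "measured", "known", "first", "only" and "open" are said of these compounds alone.

Compound 1 `CN(C)CCCNc1ccc(/N=N/c2ccc([N+](=O)[O-])cc2)cc1` was tested in an ADME assay on MT4 cells (Homo sapiens) for cytotoxicity, read by MTT assay, with a stated time of 96 h (a higher number here means that more compound is tolerated, a lower number that less compound is tolerated), where compound 1 gives 19000 nM. Among the values that are actual numbers, compound 1 sits lowest: compound 2 `CN(/N=N/c1ccccc1)c1ccccc1` gives 55000 nM, which lies beyond the scatter above it. Compound 3 `CN1CCN(/N=N/c2cc(F)ccc2F)CC1` gives > 100000 nM, and this is the limit of > 100000 nM in this assay, at which 1 of the 3 values shown sits, a limit of the assay rather than a number. Compound 4 `Cc1ccc(/N=N/c2ccc(NCCCN(C)C)cc2)cc1` has not yet been measured. It differs from compound 1 in one spot: methyl in place of nitro on an aromatic carbon. Going by the values given here, no measured pair shows how such a swap shifts tolerance here, so the expected step, a 1.3-fold higher number from compound 1 to compound 4 (0.12 log units; within the scatter), is estimated to stay within the scatter or lean slightly toward more compound tolerated. Compound 4 is therefore expected to give about 25000 nM, likely between 8000 nM and 80000 nM.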

Compound 4, half-maximal cytotoxic concentration: 17000 nM
For compound 4 the middle estimate is 1.5-fold (0.17 log units) above the measured one; the measured number falls inside the stated range.
By their numbers in this assay, from the lowest: compounds 4 and 1 (each within the scatter of the next); then compound 2. At a limit, above all of these: compound 3.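

In this assay, going by these compounds alone, the swap of nitro for methyl gives a 1.1-fold lower number from compound 1 to compound 4 (0.05 log units; within the scatter) and is the first single-place change that can be read at this position. Compound 1 and compound 4 therefore cannot be told apart here, so the nitro group is not needed for the cytotoxicity seen with compound 1. Nothing measured here explains this result. On these data alone, whether an amine or a carboxylic acid at this position would also stay within the scatter remains open. One pair also cannot show whether this swap behaves alike on another core.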